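The compounds below may be only part of what the source reports. "The series", "measured", "known", "first", "only" and "open" are said of these compounds alone.

Compound 1 `CCOCc1cc(CN2CCCC2)c(O)c2ncccc12`: 5250 nM
Compound 2 `COCc1cc(CN2CCCCC2)c(O)c2ncccc12`: 7590 nM

In a functional assay on MES-SA/Dx5 cells (Homo sapiens) for inhibition, with a stated time of 72 h, in the presence of a further agent that is not named here (on this read-out lower numbers stand for stronger inhibition and higher numbers for weaker inhibition), compound 2 gives 7590 nM. This puts it within the usual scatter of compound 1, which gives 5250 nM, so the two numbers cannot be ranked against each other.

The next compound, compound 3 `CCOCc1cc(CN2CCCCC2)c(O)c2ncccc12`, has not yet been measured. It is built from compound 2 by a single structural change: methyl in place of hydrogen on a saturated chain carbon bound to an oxygen on a saturated carbon. In words, a methyl takes the place of a hydrogen on a saturated chain carbon bound to an oxygen on a saturated carbon, so methoxymethyl becomes ethoxymethyl.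

Among the compounds with values here, no two measured compounds differ in just one place, so the data give no direct size for this change. With so little to go on, the expectation in this assay is no step beyond the scatter, in either direction. The expected 1.2-fold lower number from compound 2 to compound 3 (0.07 log units; within the scatter) is therefore a modest one. For compound 3 the estimated value is 6500 nM, with an expected range of 3200 nM to 13000 nM.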

Compound 3, half-maximal inhibitory concentration: 7080 nM
Estimate against measurement, compound 3: 1.1-fold (0.04 log units) below; measured number inside the range.
By their numbers in this assay, from the lowest: compounds 1, 3 and 2 (each within the scatter of the next).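

In this assay, methoxymethyl becomes ethoxymethyl with a 1.1-fold lower number from compound 2 to compound 3 (0.03 log units; within the scatter) in this pair, so a methyl on a saturated chain carbon bound to an oxygen on a saturated carbon causes no change that can be told from the scatter. Compound 3 also links to compound 1 through a single swap: piperidin-1-yl in place of pyrrolidin-1-yl on a saturated chain carbon bound to an aromatic carbon gives a 1.3-fold higher number from compound 1 to compound 3 (0.13 log units; within the scatter) and so shows no readable change either. Nothing else in hand bears on why these two swaps leave the read-out in place.

As far as these compounds go, each change rests on a single pair of compounds in one assay, so whether either would behave the same way on a different partner remains open. From the compounds shown here alone, it is also open what a clearly larger change would do at these two places, such as a longer chain like butoxymethyl on the oxygen side, or a morpholin-4-yl group where the piperidin-1-yl stands.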